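This account rests on a few compounds, and the source may have more. Where it says the series, first, only, none or still open, it means among the compounds named here.

Of the compounds shown here, two of a shared core have been tested in an in vitro ADME assay on microsomes from liver (Homo sapiens) for pharmacokinetics, read by LC-MS, with a stated time of 10 min, tested at 1 uM; a higher number here means faster removal of the compound, a lower number slower removal. Compound 1 `CN1C[C@H](C(=O)Nc2cccc(F)c2)[C@@H](c2ccc(/C=C/C(=O)Nc3ccccc3N)cc2)C1` gives 6 mL/min/kg in this assay. For the measured compounds named here, compound 2 `COc1cccc(NC(=O)[C@H]2CN(C)C[C@@H]2c2ccc(/C=C/C(=O)Nc3ccccc3N)cc2)c1` gives 14 mL/min/kg in this assay, the higher of the two numbers; the only measured step, a 2.3-fold higher number from compound 1 to compound 2 (0.37 log units; beyond the scatter), lies beyond the scatter and shows that changing the ring carried by the amide nitrogen can shift the read-out. Compound 3 `Cc1ccc(NC(=O)[C@H]2CN(C)C[C@@H]2c2ccc(/C=C/C(=O)Nc3ccccc3N)cc2)cn1` has not yet been measured in this assay. It differs from compound 2 in one place: 6-methylpyridin-3-yl in place of 3-methoxyphenyl on an amide-type nitrogen. Going by the values given here, no measured step covers this exact swap, since the one step known exchanges a fluoro for a methoxy rather than replacing the whole ring, so it gives only a rough sense of scale for changes at this position. The expected step is therefore small, a 1.6-fold lower number from compound 2 to compound 3 (0.19 log units; within the scatter), with the direction uncertain. The estimate for compound 3 in this assay is 9 mL/min/kg, with a likely range from 4 mL/min/kg to 18 mL/min/kg.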

Compound 3, clearance: 8 mL/min/kg
Beside the measured number, compound 3's estimate is 1.1-fold (0.05 log units) above it; measured number inside the range.
By their numbers in this assay, from the lowest: compounds 1, 3 and 2 (each within the scatter of the next, the first and the last beyond it).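

For the compounds shown here, this is the first step at this position that replaces the whole ring on the amide-type nitrogen rather than one group on it. In this assay, 6-methylpyridin-3-yl in place of 3-methoxyphenyl gives one step (a 1.8-fold lower number from compound 2 to compound 3 (0.24 log units; within the scatter)), and the same group in place of 3-fluorophenyl gives another (a 1.3-fold higher number from compound 1 to compound 3 (0.12 log units; within the scatter)), so a ring with one hetero atom reads within the scatter of both rings of carbon only, even though those two compounds stand apart from each other (a 2.3-fold higher number from compound 1 to compound 2 (0.37 log units; beyond the scatter)). Nothing available explains these numbers in terms of the groups involved.

Compound 3 differs from compound 1 and compound 2 in both the ring nitrogen and the methyl group, so the three compounds cannot show what either change does alone; an unsubstituted pyridin-3-yl or a 4-methylphenyl group on the same nitrogen would separate the two. From the compounds shown here alone, it also remains open how the read-out would respond to a ring that is not aromatic, such as cyclohexyl, or to a short chain such as ethyl at this position.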